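A few compounds are considered here, and "the series" means these few. Any claim that something is new, unique, unknown or untested is made for them only; others in the source may bear on it.

Compound 1 `CCCCNc1nc(SCC)nc2ncccc12` gives 9200 nM in a functional assay on MDA-MB-231 cells (Homo sapiens) for cytotoxicity, read by neutral red uptake, with a stated time of 72 h (on this read-out lower numbers stand for stronger inhibition and higher numbers for weaker inhibition), the higher of the two numbers recorded so far. Going by the values given here, its only measured neighbour is compound 2 `CCCCCCCNc1nc(SCC)nc2ncccc12`, which gives 2600 nM in this assay; the change between them is a 3.5-fold lower number from compound 1 to compound 2 (0.55 log units; beyond the scatter), a lengthening of the chain on the aromatic nitrogen. Compound 3 `CCCCNc1nc(SC(C)C)nc2ncccc12` differs from compound 1 in another place: methyl in place of hydrogen on a saturated chain carbon bound to a saturated chain carbon and a sulfur. Among the compounds with values here, no measured step touches the ethylsulfanyl side of the shared core, so the single step known, from compound 1 to compound 2, bears only indirectly on this change, and it concerned a different chain. Within the data shown here, with no direct precedent, the expected step from compound 1 to compound 3 is small, a 1.2-fold lower number from compound 1 to compound 3 (0.06 log units; within the scatter), and may well lie within the scatter. Compound 3 is therefore estimated at 8000 nM in this assay, with a range from 3000 nM to 25000 nM.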

Compound 3, half-maximal inhibitory concentration: 15700 nM
For compound 3 the middle estimate is 2.0-fold (0.29 log units) below the measured one; the range from low to high includes it.
By their numbers in this assay, from the lowest: compound 2; then compounds 1 and 3 (each within the scatter of the next).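

In this assay, the ethylsulfanyl side of the shared core now has its first measured step: ethylsulfanyl to isopropylsulfanyl gives a 1.7-fold higher number from compound 1 to compound 3 (0.23 log units; within the scatter), so compound 3 cannot be told apart from compound 1 on this read-out. The step on the aromatic nitrogen chain, a 3.5-fold lower number from compound 1 to compound 2 (0.55 log units; beyond the scatter), lies beyond the scatter, whereas this added methyl does not. No measurement is available that would account for the result of this change.

Still open, from the compounds shown here alone, is whether a longer chain or a benzyl group in place of the ethyl of ethylsulfanyl, or a carboxylic acid or an amine carried on that chain, would give a step beyond the scatter. Also open, going by these compounds, is whether ethylsulfanyl to isopropylsulfanyl gives a similar step when the longer nitrogen chain of compound 2 is present.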